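The source may hold more compounds than are shown below. What is called first, only, known or untested is meant among the compounds shown, and "the series" means these compounds.

Compound 3 `COc1ccc(-c2cnc(NC(=O)c3ccccc3Cl)n2C)cc1` carries a 2-chlorophenyl group on a carbonyl carbon. In a toxicity assay on THP-1 cells (Homo sapiens) for inhibition (a higher number here means that more compound is tolerated, a lower number that less compound is tolerated), compound 3 gives > 50000 nM, which is a limit of the assay rather than a number. Compound 1 `CCCC(=O)Nc1ncc(-c2ccc(OC)cc2)n1C` gives > 100000 nM in this assay, likewise a limit. Compound 2 `COc1ccc(-c2cnc(NC(=O)C3CCNCC3)n2C)cc1` gives > 100000 nM, again only a limit. Going by the values given here, the steps a step that the two limits leave unreadable from compound 1 to compound 2, a step that the two limits leave unreadable from compound 1 to compound 3 and a step that the two limits leave unreadable from compound 2 to compound 3 cannot be read because the limit of > 100000 nM in this assay, at which 2 of the 3 values shown sit, and the limit of > 50000 nM in this assay, at which 1 of the 3 values shown sits, are the only evidence the three values give. Compound 4 `COc1ccc(-c2cnc(NC(=O)c3ccno3)n2C)cc1` differs from compound 3 by 1,2-oxazol-5-yl in place of 2-chlorophenyl on a carbonyl carbon. Among the compounds with values here, no measured step bears on this change, so for compound 4 no step beyond the scatter is expected, the expected step being a step that the limit leaves unreadable from compound 3 to compound 4. Compound 4 is therefore estimated at 100000 nM, with a range from 50000 nM to 200000 nM.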

Compound 4, half-maximal cytotoxic concentration: > 100000 nM
Compound 4 ended at the assay's limit; the forecaster's own chance of this, stated with the estimate: 85%; the middle value lies on the limit itself.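

Compound 4 gives only a limit in this assay, as do compound 1, compound 2 and compound 3, so no step among these four compounds can be read. Where the true tolerated concentration of each lies remains open.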